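From phenyl to 4-chlorophenyl at the assay limit

This account rests on a few compounds, and the source may have more. Where it says the series, first, only, none or still open, it means among the compounds named here.

Measured in a functional assay on thoracic aorta (Rattus norvegicus, strain Wistar), with a stated time of 15 min; on this read-out higher numbers stand for an effect only at larger amounts of compound and lower numbers for an effect already at smaller amounts:
Compound 1 `CCOc1ccc(F)cc1C(C)NC(=O)NS(=O)(=O)c1ccc(Cl)cc1`: > 300000 nM
Compound 2 `CCOc1ccc(Br)cc1C(C)NC(=O)NS(=O)(=O)c1ccccc1`: > 300000 nM

Both entries are limits of the assay, not numbers. Compound 2 gives > 300000 nM, which is a limit, and it shares (the limit of > 300000 nM in this assay, at which 2 of the 2 values shown sit). Compound 3 `CCOc1ccc(Br)cc1C(C)NC(=O)NS(=O)(=O)c1ccc(Cl)cc1` differs from compound 2 by chloro in place of hydrogen on an aromatic carbon, para to a large group, which turns phenyl to 4-chlorophenyl (chloro in place of hydrogen on an aromatic carbon). Within the data shown here, no measured pair shows this change alone. Compound 1 already carries a 4-chlorophenyl and gives > 300000 nM, again a limit. On that basis, little change is expected in this assay, and a limit is the likeliest report. The expected step of an at least 1.5-fold lower number from compound 2 to compound 3 (0.17 log units; that floor lies within the scatter) is small, and any shift would be towards smaller amounts. Compound 3 is estimated at 200000 nM, with an expected range from 50000 nM to 300000 nM.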

Compound 3, half-maximal effective concentration: 171000 nM
Compound 3: middle estimate off by 1.2-fold (0.07 log units), on the high side; the measured number falls inside the stated range.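

In this assay, among these compounds, compound 3 at 171000 nM is the only one of the three compounds that reads as a number, so 4-chlorophenyl and bromo together first bring a measurable effect into the range of this assay. Chloro in place of hydrogen gives an at least 1.7-fold lower number from compound 2 to compound 3 (0.24 log units; that floor lies within the scatter), and bromo in place of fluoro gives an at least 1.7-fold lower number from compound 1 to compound 3 (0.24 log units; that floor lies within the scatter), so neither change is shown by itself to move the read-out beyond the usual scatter. Compound 1 and compound 2 remain limits of the assay, not numbers: the limit of > 300000 nM in this assay, at which 2 of the 3 values shown sit.

As far as these compounds go, both steps start from a limit, so their true size stays open. Also open, from the compounds shown here alone, is whether a methyl, a nitrile or an amine in place of the chloro on the 4-chlorophenyl would still give a number in this assay.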